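Bromo-methoxyphenyl replaces methylphenyl on the five-membered ring

The compounds below may be only part of what the source reports. "The series", "measured", "known", "first", "only" and "open" are said of these compounds alone.

Measured so far:
Compound 1, `COc1cc(C(=O)c2cn(-c3ccccc3[N+](=O)[O-])cc2-c2ccccc2)cc(OC)c1OC`: 5000 nM
Compound 2, `COc1cc(C(=O)c2cn(-c3cccc(Br)c3)cc2-c2ccccc2)cc(OC)c1OC`: 78 nM
Compound 3, `COc1cc(C(=O)c2cn(-c3ccccc3)cc2-c2ccccc2C)cc(OC)c1OC`: 190 nM

In a functional assay on MCF7 cells (Homo sapiens) for cytotoxicity, read by MTT assay, with a stated time of 96 h (a lower number here means a stronger inhibitor, a higher number a weaker inhibitor), compound 3 gives 190 nM, the second highest of the three numbers. Compound 2 gives a lower number, and the gap between the two lies beyond the scatter; compound 1 gives a far higher number than compound 3. Compound 4, `COc1ccc(Br)cc1-c1cn(-c2ccccc2)cc1C(=O)c1cc(OC)c(OC)c(OC)c1`, has not yet been measured in this assay. It differs from compound 3 in one place: 5-bromo-2-methoxyphenyl in place of 2-methylphenyl on an aromatic carbon.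

Within the data shown here, the only measured step, a 64-fold lower number from compound 1 to compound 2 (1.81 log units; beyond the scatter), concerns a change on the aromatic nitrogen, not on the aromatic carbon where compound 4 differs, so it does not bear directly on this change. Among the measured compounds shown here, no measured pair shows what a bromine or a methoxy on the phenyl group at this carbon does. The expected step is therefore uncertain and modest. Compound 4 is expected to give 150 nM, with a range from 40 nM to 600 nM. This amounts to an expected step of a 1.3-fold lower number from compound 3 to compound 4 (0.10 log units; within the scatter), well within the spread of the measured values.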

Compound 4, half-maximal inhibitory concentration: 2200 nM
Compound 4: middle estimate off by 15-fold (1.17 log units), on the low side; the whole stated range lies below it.
By their numbers in this assay, from the lowest: compound 2; then compound 3; then compound 4; then compound 1.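

In this assay, the change at the aromatic carbon two ring bonds from the ring nitrogen gave a 12-fold higher number from compound 3 to compound 4 (1.06 log units; beyond the scatter) when 5-bromo-2-methoxyphenyl took the place of 2-methylphenyl. Among these compounds, this is the first measured change at this carbon, and it shows that the number responds strongly to the group here, not only to the group on the ring nitrogen. No measurement among these compounds accounts for the rise.

The change brings in a bromine and a methoxy together and removes a methyl, so the compounds shown do not separate the share of each, as a plain 2-methoxyphenyl or 3-bromophenyl at this carbon would. From the compounds shown here alone, what an amine or a hydroxyl on this phenyl would give also remains open.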